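A few compounds are considered here, and "the series" means these few. Any claim that something is new, unique, unknown or untested is made for them only; others in the source may bear on it.

Working notes on the series. Compound 1 (`NC(=O)Nc1sc(-c2ccccc2)cc1C(=O)NC1CCCCC1`) has no usable number in a functional assay on HT-29 cells (Homo sapiens); a lower number here means that less compound is needed, a higher number that more compound is needed for the effect ("not determined" (no result reported)), so it offers no starting value for the step to compound 4 (`NCCNC(=O)c1cc(-c2ccccc2)sc1NC(N)=O`). The structural change is 2-aminoethyl in place of cyclohexyl on an amide-type nitrogen.

Within the data shown here, the only numbers available come from two other compounds. In this assay compound 2 (`NC(=O)Nc1sc(-c2ccc(Cl)cc2)cc1C(=O)N[C@H]1CCCNC1`) gives 40 nM and compound 3 (`NC(=O)Nc1sc(-c2ccc(C(N)=O)cc2)cc1C(=O)N[C@H]1CCCNC1`) gives 3200 nM. Among the measured compounds shown here, the single measured step (an 80-fold higher number from compound 2 to compound 3 (1.90 log units; beyond the scatter)) is large, but it is carbamoyl in place of chloro on an aromatic carbon, not a change on the amide-type nitrogen. It therefore bears on the present change only indirectly: it shows how far values can move within this small set, not which way 2-aminoethyl will move them.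

For the measured compounds named here, no measured compound carries either cyclohexyl with a value or 2-aminoethyl, and so no size or direction can be expected for the step itself. The expectation rests instead on the span from compound 2 (40 nM) to compound 3 (3200 nM), and it stays wide. In this assay the estimated value for compound 4 is 800 nM, expected to lie between 120 nM and 5000 nM.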

Compound 4, half-maximal effective concentration: 960 nM
The estimate for compound 4 lay 1.2-fold (0.08 log units) below the measured number; measured number inside the range.
By their numbers in this assay, from the lowest: compound 2; then compound 4; then compound 3.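

In this assay compound 1 stands at "not determined" (no result reported), so the step from compound 1 to compound 4 cannot be read. The compounds shown leave open whether 2-aminoethyl in place of cyclohexyl on the amide-type nitrogen raises or lowers the number, and by how much. Nothing available explains the value of compound 4.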